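The source may report more compounds than this note shows. Statements on the series, on what has been measured and on what is new or still open speak of the compounds shown alone.

Measured in an ADME assay on L1210/0 cells (Mus musculus) for cytotoxicity, with a stated time of 48 h; on this read-out lower numbers stand for stronger inhibition and higher numbers for weaker inhibition:
- Compound 1 `O=c1[nH]c(=O)n([C@H]2C[C@H](O)[C@@H](CO)O2)cc1C#CCCCO`: > 200000 nM, a limit
- Compound 2 `O=c1[nH]c(=O)n([C@H]2C[C@H](O)[C@@H](CO)O2)cc1C#Cc1ccccc1`: > 200000 nM, a limit
- Compound 3 `CCCc1cn([C@H]2C[C@H](O)[C@@H](CO)O2)c(=O)[nH]c1=O`: > 200000 nM, a limit

Compound 3 has no number in this assay, only the limit > 200000 nM. Compound 1 and compound 2 are limits of the same kind, so the three cannot be ranked: the limit of > 200000 nM in this assay, at which 3 of the 3 values shown sit.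

The next structure is compound 4 `O=c1[nH]c(=O)n([C@H]2C[C@H](O)[C@@H](CO)O2)cc1C1SCCS1`, which differs from compound 3 in one place: a group of 5 heavy atoms (3 carbon, 2 sulfur; one five-membered non-aromatic ring with 2 hetero atoms) in place of a group of 3 heavy atoms (3 carbon; no ring), on an aromatic carbon. Propyl leaves, and a group with one five-membered non-aromatic ring with 2 hetero atoms enters on the same aromatic carbon.

Two measured steps change this same carbon: a step that the two limits leave unreadable from compound 1 to compound 3, and a step that the two limits leave unreadable from compound 2 to compound 3. A third, a step that the two limits leave unreadable from compound 1 to compound 2, changes the group on a triple-bonded carbon. None of them has a readable size, so they offer no measured guide to how large a change at this carbon can be. All three compounds nevertheless stay at the limit, and compound 4 is expected to do the same. No step beyond the usual scatter is expected, in either direction, because of the limit of > 200000 nM in this assay, at which 3 of the 3 values shown sit. The expected step is a number no higher from compound 3 to compound 4 (the limit leaves the size open). Compound 4 is estimated at 200000 nM, with an expected range from 80000 nM to 400000 nM.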

Compound 4, half-maximal inhibitory concentration: > 200000 nM
Compound 4: only a limit was reported; the forecaster's own chance of this, stated with the estimate: 85%; the middle value sits exactly at the limit.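

In this assay compound 4 gives only a limit, > 200000 nM. Its steps from compound 1, compound 2 and compound 3 cannot be read, and the four compounds cannot be ranked: the limit of > 200000 nM in this assay, at which 4 of the 4 values shown sit.

The compounds shown leave open how strongly any of the four acts on these cells, and whether changing the group on this aromatic carbon shifts the read-out at all.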